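The compounds below may be only part of what the source reports. "The series", "measured", "known", "first", "only" and "open" are said of these compounds alone.

Three compounds have numbers in a functional assay on SK-N-SH cells (Homo sapiens) for cytotoxicity, read by MTT assay, with a stated time of 24 h; a higher number here means a weaker inhibitor, a lower number a stronger inhibitor. Compound 1 `C/C(=N\NC(=O)/C(C#N)=C/c1ccc(O)cc1)c1c(O)c2ccc(O)cc2oc1=O` gives 8120 nM, at the low end of the three. Compound 2 `COc1cc(/C=C(\C#N)C(=O)N/N=C(\C)c2c(O)c3ccc(O)cc3oc2=O)ccc1O` gives 14400 nM, and compound 3 `COc1ccc(/C=C(\C#N)C(=O)N/N=C(\C)c2c(O)c3ccc(O)cc3oc2=O)cc1OC` gives 21500 nM. Adding methoxy on an aromatic carbon gave a 1.8-fold higher number from compound 1 to compound 2 (0.25 log units; within the scatter), methyl in place of hydrogen on an oxygen gave a 1.5-fold higher number from compound 2 to compound 3 (0.17 log units; within the scatter), and 3,4-dimethoxyphenyl in place of 4-hydroxyphenyl gave a 2.6-fold higher number from compound 1 to compound 3 (0.42 log units; beyond the scatter). Compound 4 `C/C(=N\NC(=O)/C(C#N)=C/c1ccc(Br)cc1)c1c(O)c2ccc(O)cc2oc1=O` differs from compound 1 by bromo in place of hydroxy on an aromatic carbon. Within the data shown here, no measured compound carries bromo, so these steps bear on it only as changes to the same aromatic group. In this assay, a small step toward a higher number is therefore expected, not exceeding the size of the largest step above. The expected change is a 1.6-fold higher number from compound 1 to compound 4 (0.20 log units; within the scatter). Compound 4 is estimated at 13000 nM, with an expected range from 5000 nM to 32000 nM.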

Compound 4, half-maximal inhibitory concentration: 12100 nM
Beside the measured number, compound 4's estimate is 1.1-fold (0.03 log units) above it; the range from low to high includes it.
By their numbers in this assay, from the lowest: compounds 1, 4, 2 and 3 (each within the scatter of the next, the first and the last beyond it).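

In this assay, bromo in place of hydroxy takes away the hydrogen-bond donor and acceptor at this position, yet the step stays within the scatter (a 1.5-fold higher number from compound 1 to compound 4 (0.17 log units; within the scatter)), so on this core the number does not depend on that hydroxy. The 4-bromophenyl also stays within the scatter of both methoxy-bearing groups (a 1.2-fold lower number from compound 2 to compound 4 (0.08 log units; within the scatter)) and (a 1.8-fold lower number from compound 3 to compound 4 (0.25 log units; within the scatter)). Nothing measured here explains this. Going by these compounds, whether an amine or a carboxylic acid at this position would keep the number in this range stays open, as does whether any group here could give a clearly lower number than compound 1.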